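Lengthening the alkyl chain on a weak inhibitor

The source may hold more compounds than are shown below. What is called first, only, known or untested is meant among the compounds shown, and "the series" means these compounds.

Compound 1 `COc1cc(-c2noc(-c3ccc(N)cc3)n2)cc(OC)c1OC` carries an amino group on one aromatic ring, and in a functional assay on cells (Splenocyte, Mus musculus, strain BALB/c) for inhibition, read by scintillation counting and thymidine incorporation, with stated times of 48 h and 8 h (on this read-out higher numbers stand for weaker inhibition and lower numbers for stronger inhibition), compound 1 gives 800 nM. Compound 2 `CCCCc1ccc(-c2nc(-c3cc(OC)c(OC)c(OC)c3)no2)cc1` differs by butyl in place of amino on an aromatic carbon. In this assay compound 2 gives > 50000 nM, which is a limit of the assay rather than a measured number. The step of an at least 62-fold higher number from compound 1 to compound 2 (1.79 log units; beyond the scatter) thus shows inhibition falling away to the edge of what the method records, so compound 2 stands at the weak end of the two values shown, sitting at the limit described by the limit of > 50000 nM in this assay, at which 1 of the 2 values shown sits.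

Compound 3 `CCCCCCc1ccc(-c2nc(-c3cc(OC)c(OC)c(OC)c3)no2)cc1` is not yet measured. It differs from compound 2 by ethyl in place of hydrogen on a saturated chain carbon, four bonds along the chain from an aromatic carbon. Among the compounds with values here, the only measured step bears on it indirectly: it shows that a butyl group already pushed inhibition past the limit. Within the data shown here, no measured pair shows what lengthening the chain further does. Given this starting point, the expected result for compound 3 in this assay is 100000 nM, between 30000 nM and 500000 nM. The expected step that the limit leaves unreadable from compound 2 to compound 3 would therefore be nothing the assay could resolve, most likely another reported limit.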

Compound 3, half-maximal inhibitory concentration: 23800 nM
Estimate against measurement, compound 3: 4.2-fold (0.62 log units) above; the measured number lies below the stated range.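

Adding ethyl on the saturated chain, four bonds along the chain from an aromatic carbon, gives an at least 2.1-fold lower number from compound 2 to compound 3 (0.32 log units; beyond the scatter) in this assay, so inhibition returns to a range where a number can be read, and the far end of this chain still matters to the result. The true size of that step stays unknown, because compound 2 has only a limit of the assay and not a measured number: the limit of > 50000 nM in this assay, at which 1 of the 3 values shown sits.

Set against the amino group, however, the longer chain remains well behind, with a 30-fold higher number from compound 1 to compound 3 (1.47 log units; beyond the scatter), so the recovery along the chain does not bring back what the amino group gave.

Two alkyl chains, one of them read only as a limit, cannot show whether inhibition would keep improving with an octyl chain or would stop improving beyond hexyl. As far as these compounds go, it also remains open how a hexyl chain ending in an amine or a carboxylic acid would compare with compound 3, and whether such a chain could approach the amino compound.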